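This account rests on a few compounds, and the source may have more. Where it says the series, first, only, none or still open, it means among the compounds named here.

Measured compounds:
- compound 1 `COc1ccc(OC)c(/C=N/NC(=O)Nc2ccc(Oc3ccnc(-c4nncn4CCN(C)C)c3)c(F)c2)c1` — in an ADME assay on WI-38 cells (Homo sapiens) for cytotoxicity, read by MTT assay, with a stated time of 72 h (a lower number here means a stronger inhibitor, a higher number a weaker inhibitor), compound 1 gives "not determined" (no result reported)
- compound 2 `CN(C)CCn1cnnc1-c1cc(Oc2ccc(NC(=O)N/N=C/c3ccc(Cl)cc3)cc2F)ccn1` — 1870 nM
- compound 3 `CN(C)CCn1cnnc1-c1cc(Oc2ccc(NC(=O)N/N=C/c3cc(Br)c(O)c(Br)c3)cc2F)ccn1` — in this assay compound 3 gives "not determined" (no result reported)

Of the three measured compounds, only compound 2 carries a number in this assay, where compound 2 gives 1870 nM. Compound 3 stands without a single number; the set contains one further entry of the same kind, compound 1, so compound 3 cannot be placed in order against any partner on the numbers shown. Compound 4 `CN(C)CCn1cnnc1-c1cc(Oc2ccc(NC(=O)N/N=C/c3c(O)ccc4ccccc34)cc2F)ccn1` has not yet been measured in this assay. It differs from compound 3 in one place: 2-hydroxynaphthalen-1-yl in place of 3,5-dibromo-4-hydroxyphenyl on a carbon with a double bond to nitrogen. For the measured compounds named here, no step between measured compounds that differ in one place is known, so nothing about the size of such a change in this assay can be drawn from the data themselves. Going by the values given here, the only anchor is the value of compound 2, 1870 nM, which suggests the range in which this series sits. For the step from compound 3 to compound 4 no direction can be expected beyond the scatter, and the estimate for compound 4 rests on the series rather than on a measured change. Compound 4 is expected to give about 2500 nM in this assay, with a range from 600 nM to 10000 nM.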

Compound 4, half-maximal inhibitory concentration: 3250 nM
For compound 4 the middle estimate is 1.3-fold (0.11 log units) below the measured one; the range from low to high includes it.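

In this assay, 2-hydroxynaphthalen-1-yl in place of 4-chlorophenyl on a carbon with a double bond to nitrogen gives a 1.7-fold higher number from compound 2 to compound 4 (0.24 log units; within the scatter). This position therefore accepts a group with 2 six-membered aromatic rings of carbon only, in place of a group with one such ring, without a change that can be told from the scatter, although this rests on a single pair of compounds. The steps from compound 1 and from compound 3 to compound 4 cannot be read, as neither of those two compounds has a number in this assay, and nothing measured here accounts for the result.

On these data alone, it remains open whether the hydroxyl group of compound 4 or its second ring counts for more at this position, as would be tested by an unsubstituted naphthalen-1-yl group, and whether a position with a carboxylic acid, a morpholine or a pyridine ring would move the number beyond the scatter. All the compounds shown share the same core, so it is also open how far the number depends on any part of the molecule other than this one position.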